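Swapping the ring on the amine nitrogen of compound 2

The source may report more compounds than this note shows. Statements on the series, on what has been measured and on what is new or still open speak of the compounds shown alone.

Of the compounds shown here, two sharing a common core have been measured in a functional assay for antagonist activity at Alpha-1A adrenergic receptor (Homo sapiens), read by FLIPR, with a stated time of 10 min; a higher number here means a weaker inhibitor, a lower number a stronger inhibitor. Compound 1, `CNC(=O)c1cc(OCCCCN2CCC(c3noc4cc(F)ccc34)CC2)ccn1`, gives 11 nM. Compound 2, `CNC(=O)c1cc(OCCCCN2CCN(c3nsc4ccccc34)CC2)ccn1`, gives 71 nM, the higher of the two numbers, and the gap between compound 1 and compound 2 lies beyond the usual scatter of repeated measurements, so compound 2 is the weaker inhibitor of the pair.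

Compound 3, `CNC(=O)c1cc(OCCCCN2CCN(c3cccc4sccc34)CC2)ccn1`, has not been measured. It differs from compound 2 in one place: a group of 9 heavy atoms (8 carbon, 1 sulfur; one five-membered aromatic ring with 1 hetero atom, one six-membered aromatic ring of carbon only) in place of a group of 9 heavy atoms (7 carbon, 1 nitrogen, 1 sulfur; one five-membered aromatic ring with 2 hetero atoms, one six-membered aromatic ring of carbon only), on an amine nitrogen in a ring. The entering group, 1-benzothiophen-4-yl, keeps the same count of heavy atoms but carries one fewer hydrogen-bond acceptor, since the nitrogen in the five-membered aromatic ring is gone.

Within the data shown here, no measured pair in this set shows what such a swap does, so the expectation rests on the two values at hand. The change from compound 2 to compound 3 is expected to shift the number by about a 1.8-fold lower number from compound 2 to compound 3 (0.25 log units; within the scatter), towards somewhat stronger inhibition, though a result within the scatter of compound 2 would not be surprising. In this assay compound 3 is therefore estimated at 40 nM, with a plausible range from 10 nM to 150 nM.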

Compound 3, half-maximal inhibitory concentration: 164 nM
The estimate for compound 3 lay 4.1-fold (0.61 log units) below the measured number; the whole stated range lies below it.
By their numbers in this assay, from the lowest: compound 1; then compound 2; then compound 3.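

Among these compounds, this is the first direct reading of what a swap of the group on this amine nitrogen does in this assay: the result is a 2.3-fold higher number from compound 2 to compound 3 (0.36 log units; beyond the scatter) and so a modest move towards weaker inhibition. At this position, then, the group that leaves does better than 1-benzothiophen-4-yl, even though the two have the same count of heavy atoms and the change amounts to a carbon in place of a nitrogen in the five-membered aromatic ring, with one hydrogen-bond acceptor fewer. Nothing at hand explains the rise, and this single step cannot separate the lost acceptor from any other difference between the two groups.

The compounds shown leave open how simpler or differently shaped groups on this nitrogen, such as a phenyl ring or a naphthyl group, would compare with these two. They also leave open whether the same swap would give a step of similar direction and size on the core of compound 1, or with a chain shorter than the one shared here.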